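A few compounds are considered here, and "the series" means these few. Any claim that something is new, unique, unknown or untested is made for them only; others in the source may bear on it.

Measured so far in an ADME assay on MRC5 cells (Homo sapiens) for cytotoxicity, read by MTT assay; a higher number here means that more compound is tolerated, a lower number that less compound is tolerated:
compound 1, `CCCCCCC#Cc1cn([C@@H]2O[C@H](CO)[C@@H](O)[C@H]2O)c(=O)[nH]c1=O`, 15700 nM
compound 2, `C[Si](C)(C)C#Cc1c[nH]c(=O)[nH]c1=O`, 124000 nM
compound 3, `O=c1[nH]cc(C#CC2CCCCC2)c(=O)[nH]1`, 62800 nM

Compound 1 stands lowest of the three numbers in this assay, which means it is the least well tolerated of the three. Compound 3 is the nearest to it, and compound 2 is the furthest away; both of those gaps are beyond the usual scatter, so compound 1 is genuinely less tolerated than either. No pair of these compounds differs in only one place, so nothing can be said about any single change among them beyond what the three values show.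

The compound to be measured next is compound 4, `O=c1[nH]c(=O)n([C@@H]2O[C@H](CO)[C@@H](O)[C@H]2O)cc1C#CC1CC1`. It differs from compound 1 in one place: cyclopropyl in place of hexyl on a triple-bonded carbon. The two compounds that carry a smaller or ring-shaped group on the triple bond, compound 2 and compound 3, both sit well above compound 1, so the expectation for compound 4 is a step upward, toward a higher tolerated concentration, of a size that may reach beyond the scatter, expressed as a 2.5-fold higher number from compound 1 to compound 4 (0.41 log units; beyond the scatter). On that basis compound 4 is estimated at 40000 nM, with a likely range from 15000 nM to 110000 nM.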

Compound 4, half-maximal cytotoxic concentration: 24200 nM
For compound 4 the middle estimate is 1.7-fold (0.22 log units) above the measured one, and the stated range covers the measured number.
By their numbers in this assay, from the lowest: compounds 1 and 4 (each within the scatter of the next); then compounds 3 and 2 (each within the scatter of the next).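

In this assay, within the data shown here, putting cyclopropyl in place of hexyl on a triple-bonded carbon gives a 1.5-fold higher number from compound 1 to compound 4 (0.19 log units; within the scatter) as the first direct reading of a single change at this place, so the two compounds cannot be told apart in this assay. Within this one pair, the open hexyl chain and the small cyclopropyl ring are therefore tolerated alike, even though the two groups differ in size and shape. Compound 2 and compound 3 each differ from compound 1 and compound 4 in more than one place, so this pair gives no ground for tying their higher numbers to the group on the triple bond alone.

Among these compounds, only two groups have been compared at this place on the shared core, so it remains open whether a phenyl ring, a longer chain than hexyl or a chain ending in an amine would give a step beyond the scatter. Nothing shown here gives a measured reason for how closely compound 1 and compound 4 agree, and a single cell line says nothing about other cell types.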